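Thiophen-2-yl to 1H-pyrazol-4-yl at the assay limit

A few compounds are considered here, and "the series" means these few. Any claim that something is new, unique, unknown or untested is made for them only; others in the source may bear on it.

Measured so far in a functional assay on PC-3 cells (Homo sapiens) for antiproliferative activity, read by CCK-8 assay, with a stated time of 6 days; on this read-out lower numbers stand for stronger inhibition and higher numbers for weaker inhibition 
- compound 1 (`CCN(c1ccc(C#N)c(Cl)c1)c1cc(-c2ccccc2)ccc1C`) gives "not determined" (no result reported) as its entry
- compound 2 (`CCN(c1ccc(C#N)c(Cl)c1)c1cc(-c2cccs2)ccc1C`) gives > 30000 nM as its entry

Compound 2 stands at > 30000 nM in this assay and this entry is a limit of the assay, not a number. Among the compounds with values here, compound 1 offers no result for comparison, so the series has no single number and no measured step yet.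

The next compound is compound 3 (`CCN(c1ccc(C#N)c(Cl)c1)c1cc(-c2cn[nH]c2)ccc1C`). The change is 1H-pyrazol-4-yl in place of thiophen-2-yl on an aromatic carbon with 1H-pyrazol-4-yl in place of thiophen-2-yl on an aromatic carbon, meta to a large group and para to a methyl group.

Within the data shown here, with no measured step to draw on, no step beyond the scatter can be firmly expected in this assay, though a modest move towards lower numbers, meaning stronger inhibition, is possible. The expectation starts from compound 2 with its limit of > 30000 nM as the only anchor. The estimated change is an at least 1.2-fold lower number from compound 2 to compound 3 (0.07 log units; that floor lies within the scatter) on this reasoning. Compound 3 is estimated at 25000 nM with an expected range from 6000 nM to 60000 nM as its span, and a report of only a limit remains likely.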

Compound 3, half-maximal inhibitory concentration: 15300 nM
The estimate for compound 3 lay 1.6-fold (0.21 log units) above the measured number; the measured number falls inside the stated range.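

In this assay, 1H-pyrazol-4-yl in place of thiophen-2-yl on this aromatic carbon, meta to a large group and para to a methyl group, gives an at least 1.9-fold lower number from compound 2 to compound 3 (0.29 log units; that floor lies within the scatter). Compound 3 is the only entry in the series with a single number, 15300 nM, so this position now has one measured anchor for later comparisons. The size of the step remains open on its upper side because compound 2 carries a limit of the assay and not a number: the limit of > 30000 nM in this assay, at which 1 of the 3 values shown sits.

With the floor of the step inside the usual scatter, the compounds shown do not establish whether compound 3 truly differs from compound 2, and they cannot separate the effect of the hydrogen-bond donor that enters with 1H-pyrazol-4-yl from that of the change in ring hetero atoms. Compound 1 provides no result for comparison, and the compounds shown leave open how the series would respond at this aromatic carbon to an amine, a carboxylic acid or a longer chain.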